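The source may hold more compounds than are shown below. What is called first, only, known or untested is meant among the compounds shown, and "the series" means these compounds.

Series notes.

Compound 1 `CCCCCCNc1nc(-c2ccccc2)nc2c1nnn2Cc1ccccc1` is the reference. In an assay on Cerebral cortex for displacement of a labelled ligand from adenosine receptor A1 (Bos taurus) (on this read-out higher numbers stand for weaker inhibition and lower numbers for stronger inhibition), compound 1 gives 13.2 nM. Compound 2 `CCCCCCNc1nc(-c2ccccc2)nc2c1nnn2Cc1ccccc1Cl` carries the change chloro in place of hydrogen on an aromatic carbon on the benzyl ring; in this assay compound 2 gives 31 nM, so the step of a 2.3-fold higher number from compound 1 to compound 2 (0.37 log units; beyond the scatter) weakens binding. Compound 3 `c1ccc(Cn2nnc3c(NC4CCC4)nc(-c4ccccc4)nc32)cc1` differs from compound 1 in the amine side chain, (cyclobutyl in place of hexyl on a nitrogen on an aromatic ring); in this assay compound 3 gives 5 nM, the lowest number of the three, with the step of a 2.6-fold lower number from compound 1 to compound 3 (0.42 log units; beyond the scatter) running the other way.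

Compound 4 `Clc1ccccc1Cn1nnc2c(NC3CCC3)nc(-c3ccccc3)nc21` combines the cyclobutylamino core of compound 3 with the benzyl-ring change of compound 2: chloro in place of hydrogen on an aromatic carbon. This is the same change as that from compound 1 to compound 2, made on a different core; the two cores differ as described above under the hexyl-to-cyclobutyl exchange.

For the measured compounds named here, the only precedent for this change is the step of a 2.3-fold higher number from compound 1 to compound 2 (0.37 log units; beyond the scatter), which was modest but beyond the scatter. Compound 4 is expected to show a step of about a 2.4-fold higher number from compound 3 to compound 4 (0.38 log units; beyond the scatter) from compound 3 in this assay, resting on that single precedent. Compound 4 is therefore estimated at 12 nM, between 5 nM and 28 nM.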

Compound 4, inhibition constant: 24 nM
Compound 4: the middle estimate sits 2.0-fold (0.30 log units) below what was measured, within the range that was stated.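

In this assay chloro in place of hydrogen on the benzyl ring again weakens binding on the cyclobutylamino core, with a 4.8-fold higher number from compound 3 to compound 4 (0.68 log units; beyond the scatter), and the step agrees in direction with the one on the hexylamino core, the gap between the two lying within the scatter: the same change on two cores in this assay, a 2.3-fold higher number (0.37 log units; beyond the scatter) from compound 1 to compound 2 and a 4.8-fold higher number (0.68 log units; beyond the scatter) from compound 3 to compound 4, 2.0-fold (0.31 log units) apart, within the scatter of two such steps. Read the other way, cyclobutyl in place of hexyl gives a 1.3-fold lower number from compound 2 to compound 4 (0.11 log units; within the scatter) among the 2-chlorobenzyl compounds, a step within the scatter, yet this step too cannot be told apart from its counterpart among the benzyl compounds: the same change on two cores in this assay, a 2.6-fold lower number (0.42 log units; beyond the scatter) from compound 1 to compound 3 and a 1.3-fold lower number (0.11 log units; within the scatter) from compound 2 to compound 4, 2.0-fold (0.31 log units) apart, within the scatter of two such steps. The four compounds therefore show the chloro change carrying over in direction between these two cores, but they do not show that its size depends on the core, and two pairs cannot establish a general rule.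

From the compounds shown here alone, whether fluoro or methoxy on the benzyl ring would follow chloro remains open. So does whether the same step holds with a cyclopentyl or propyl group on the amine nitrogen.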